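From 2,4-dichlorophenyl to 2,4-dimethoxyphenyl on a shared core

The source may hold more compounds than are shown below. What is called first, only, known or untested is meant among the compounds shown, and "the series" means these compounds.

- compound 1 `OC[C@H]1O[C@@H](n2cnc3c(NCc4ccccc4Cl)ncnc32)[C@H](O)[C@@H]1O` (64000 nM)
- compound 2 `OC[C@H]1O[C@@H](n2cnc3c(NCc4cccc(Br)c4)ncnc32)[C@H](O)[C@@H]1O` (19700 nM)
- compound 3 `OC[C@H]1O[C@@H](n2cnc3c(NCc4ccc(Cl)cc4Cl)ncnc32)[C@H](O)[C@@H]1O` (106000 nM)
- compound 4 `COc1ccc(CNc2ncnc3c2ncn3[C@@H]2O[C@H](CO)[C@@H](O)[C@H]2O)c(OC)c1` (not yet measured)

In a functional assay on K562 cells (Homo sapiens) for antiproliferative activity, with a stated time of 72 h (a higher number here means a weaker inhibitor, a lower number a stronger inhibitor), compound 3 gives 106000 nM and so stands level with compound 1, clearly apart from compound 2. The move to compound 4 2,4-dimethoxyphenyl in place of 2,4-dichlorophenyl on a saturated chain carbon bound to a nitrogen on an aromatic ring puts 2,4-dimethoxyphenyl in place of 2,4-dichlorophenyl on a saturated chain carbon bound to a nitrogen on an aromatic ring. Within the data shown here, two measured steps bear on it: a 1.7-fold higher number from compound 1 to compound 3 (0.22 log units; within the scatter) and a 5.4-fold higher number from compound 2 to compound 3 (0.73 log units; beyond the scatter) are the only guides, and neither involves the entering group. No step beyond the scatter is therefore expected in this assay in either direction. The estimated step is a 1.5-fold lower number from compound 3 to compound 4 (0.18 log units; within the scatter) and no more. For compound 4 the expected value is 70000 nM within an estimated range of 25000 nM to 170000 nM.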

Compound 4, half-maximal inhibitory concentration: > 166000 nM
Compound 4: a limit, no number; the forecaster's own chance of this, stated with the estimate: 15%; at least 2.3-fold (0.37 log units) between middle value and limit.
By their numbers in this assay, from the lowest: compound 2; then compounds 1 and 3 (each within the scatter of the next). At a limit, above all of these: compound 4.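

In this assay compound 4 gives a limit and not a number: the limit of > 166000 nM in this assay, at which 1 of the 4 values shown sits. At this position, on a saturated chain carbon bound to a nitrogen on an aromatic ring, 2,4-dimethoxyphenyl brings no gain over the chlorine- or bromine-bearing groups: an at least 8.4-fold higher number from compound 2 to compound 4 (0.92 log units; beyond the scatter) and an at least 2.5-fold higher number from compound 1 to compound 4 (0.41 log units; beyond the scatter) both lie beyond the scatter. Against the group it replaces, the result is less firm, as an at least 1.5-fold higher number from compound 3 to compound 4 (0.19 log units; that floor lies within the scatter) has a floor within the scatter, leaving that pair unordered. The compounds shown leave open how far the true value of compound 4 lies past its limit. They also leave open whether an amine or a carboxylic acid on the phenyl ring would behave differently.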